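The compounds below may be only part of what the source reports. "The series", "measured", "known", "first", "only" and "open" are said of these compounds alone.

Compound 1 `CCN(CC)CC#CCSc1nc2c(c(=O)[nH]c(=O)n2C)n1C`: 26400 nM
Compound 2 `Cn1cnc2nc(SCC#CCN3CCCC3)nc(SCC#CCN3CCCC3)c21`: 6810 nM

In a functional assay on C32 cells (Homo sapiens) for antiproliferative activity, read by WST assay, with a stated time of 72 h (a higher number here means a weaker inhibitor, a lower number a stronger inhibitor), compound 1 holds the higher of the two numbers, and compound 2 lies lower by a gap beyond the scatter. Compound 3 `Cn1c(SCC#CCN2CCCC2)nc2c1c(=O)[nH]c(=O)n2C` keeps the core of compound 1 and changes the amine: pyrrolidin-1-yl in place of diethylamino on a saturated chain carbon bound to a triple-bonded carbon. Within the data shown here, compound 2 also carries pyrrolidin-1-yl but has a different core, so no measured step isolates this change. The estimated move, a 1.3-fold lower number from compound 1 to compound 3 (0.12 log units; within the scatter), is expected to be slightly downward and to stay within the scatter. For compound 3 the expected value is 20000 nM, with an estimated range of 8000 nM to 50000 nM.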

Compound 3, half-maximal inhibitory concentration: 51100 nM
Compound 3: the middle estimate sits 2.6-fold (0.41 log units) below what was measured; measured number above the stated range.
By their numbers in this assay, from the lowest: compound 2; then compounds 1 and 3 (each within the scatter of the next).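

In this assay, among these compounds, the swap of diethylamino for pyrrolidin-1-yl on a saturated chain carbon bound to a triple-bonded carbon gives a 1.9-fold higher number from compound 1 to compound 3 (0.29 log units; within the scatter) and is the first single-place reading. On the core of compound 1, the open amine and the five-membered ring amine are not told apart at this position. No measurement at hand accounts for the result.

On these data alone, whether a piperidin-1-yl or morpholin-4-yl group, or a longer chain between the sulfur and the triple bond, would separate from the scatter stays open. Among the compounds shown here, compound 2 differs from compound 3 in more than one place, so no step to it can be read.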